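The source may hold more compounds than are shown below. What is called first, only, known or untested is meant among the compounds shown, and "the series" means these compounds.

Three compounds have been measured in a functional assay on PA-1 cells (Homo sapiens) for cytotoxicity, read by MTT assay, with stated times of 6 h and 48 h; on this read-out lower numbers stand for stronger inhibition and higher numbers for weaker inhibition:

Compound 1, `Cn1c(/C=C/C(=O)c2ccccc2O)cc(Br)c1Br`, gives 1250 nM.
Compound 2, `Cn1c(/C=C/C(=O)c2ccc[nH]2)cc(Br)c1Br`, gives 730 nM.
Compound 3, `O=C(/C=C/c1cc(Br)c(Br)[nH]1)c1ccccc1O`, gives 330 nM.

The difference between the core of compound 1 and the core of compound 2 is not broken down here. Their two values lie within the usual scatter of each other, so no order between them can be claimed. Compound 3 gives a lower number than compound 2, and that gap lies beyond the scatter.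

Compound 3 arises from compound 1 by one change, (hydrogen in place of methyl on an aromatic nitrogen), and this step gave a 3.8-fold lower number from compound 1 to compound 3 (0.58 log units; beyond the scatter) in this assay.

Compound 4, `O=C(/C=C/c1cc(Br)c(Br)[nH]1)c1ccc[nH]1`, has not been measured yet. It stands to compound 2 as compound 3 stands to compound 1: hydrogen in place of methyl on an aromatic nitrogen. The surroundings are not identical in wording, since in compound 1 the place is next to the ring atom that bears a large group, while in compound 2 it is next to the ring atom that bears a group of 9 heavy atoms, so this is the same kind of change rather than the same change.

For compound 4 in this assay a step of a 3.3-fold lower number from compound 2 to compound 4 (0.52 log units; beyond the scatter) is expected, because a 3.8-fold lower number from compound 1 to compound 3 (0.58 log units; beyond the scatter) was seen with the same kind of change. The estimate for compound 4 is 220 nM, expected to fall between 80 nM and 600 nM.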

Compound 4, half-maximal inhibitory concentration: 500 nM
Compound 4: the middle estimate sits 2.3-fold (0.36 log units) below what was measured, within the range that was stated.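

In this assay, hydrogen in place of methyl on the aromatic nitrogen gave a 1.5-fold lower number from compound 2 to compound 4 (0.16 log units; within the scatter), so on this core the step does not separate the two compounds. Set beside the step on the other core, it cannot be told apart from the earlier result, and the two cores therefore give no firm sign that the change behaves differently from one to the other: the same change on two cores in this assay, a 3.8-fold lower number (0.58 log units; beyond the scatter) from compound 1 to compound 3 and a 1.5-fold lower number (0.16 log units; within the scatter) from compound 2 to compound 4, 2.6-fold (0.41 log units) apart, within the scatter of two such steps This does not show that the size of the step is the same on both cores, nor that the clear step seen on the core of compound 1 also holds on the core of compound 2, and with one pair per core it says nothing about any further core in the series.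

The compounds shown leave open what a longer chain, such as ethyl or a chain ending in an amine, would do on that aromatic nitrogen in place of methyl or hydrogen. They also leave open whether the bromo groups matter, as a chloro group or a carboxylic acid in their place would test.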